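One More Methoxy on an Inactive Pair

A few compounds are considered here, and "the series" means these few. Any claim that something is new, unique, unknown or untested is made for them only; others in the source may bear on it.

In a functional assay on Bel-7402 cells (Homo sapiens) for cytotoxicity, read by MTT assay, with a stated time of 48 h (a higher number here means a weaker inhibitor, a lower number a stronger inhibitor), compound 1 (`COc1cc(NC(=O)n2cc(-c3ccc(O)cc3)n(-c3cc(OC)c(OC)c(OC)c3)c2=O)cc(OC)c1OC`) gives > 50000 nM as a limit of the assay, not a number. Compound 2 (`COc1ccc(-c2cn(C(=O)Nc3cc(OC)c(OC)c(OC)c3)c(=O)n2-c2cc(OC)c(OC)c(OC)c2)cc1`) gives > 50000 nM in this assay as well, again only a limit, so it has no measured potency to start from. Compound 3 (`COc1ccc(-c2cn(C(=O)Nc3cc(OC)c(OC)c(OC)c3)c(=O)n2-c2cc(OC)c(OC)c(OC)c2)cc1OC`) turns the 4-methoxyphenyl of compound 2 into 3,4-dimethoxyphenyl, with methoxy in place of hydrogen on an aromatic carbon as the counted difference. Among the compounds with values here, the only measured step that bears on this change is a step that the two limits leave unreadable from compound 1 to compound 2 and it also alters an oxygen-bearing aromatic ring. That step offers no size to carry forward, so no shift beyond the scatter is expected in this assay for this added methoxy. The expected change is a number no higher from compound 2 to compound 3 (the limit leaves the size open) and it remains only an estimate. For compound 3 the estimated value is 50000 nM with an expected range from 10000 nM to 100000 nM as its span.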

Compound 3, half-maximal inhibitory concentration: > 50000 nM
Compound 3: no number, only a limit; the forecaster's own chance of this, stated with the estimate: 70%; the middle value sits exactly at the limit.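

No step among compound 1, compound 2 and compound 3 can be read, because all three values are the same assay limit rather than numbers: the limit of > 50000 nM in this assay, at which 3 of the 3 values shown sit.

The compounds shown leave open whether either methoxy change alters potency in this assay, and how these three compounds rank against one another.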